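Swapping an aryloxy group for chlorine on a quinone core

The compounds below may be only part of what the source reports. "The series", "measured", "known", "first", "only" and "open" are said of these compounds alone.

Of the compounds shown here, three have been measured in a functional assay on SCLC cells (Homo sapiens) for cytotoxicity; a lower number here means a stronger inhibitor, a higher number a weaker inhibitor. Compound 1 `COc1cccc(OC2=C(Oc3cccc(OC)c3)C(=O)c3c(OC)ccc(OC)c3C2=O)c1` gives 1000 nM, the second highest of the three numbers. Compound 2 `COc1cccc(OC2=C(Cl)C(=O)c3c(OC(C)=O)ccc(OC(C)=O)c3C2=O)c1`, which carries a chloro group and acetate esters on its core, gives 5000 nM, a weaker result. Compound 3 `O=C1C=CC(=O)c2c(O)c(Oc3ccccc3)c(Oc3ccccc3)c(O)c21`, with two plain phenoxy groups and free hydroxyls, gives 100 nM, the strongest result among the three; its gaps to compound 1 and compound 2 both lie beyond the usual scatter.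

Compound 4 `COc1cccc(OC2=C(Cl)C(=O)c3c(OC)ccc(OC)c3C2=O)c1` has not yet been measured. It differs from compound 1 by chloro in place of 3-methoxyphenoxy on a double-bonded ring carbon. Among the measured compounds shown here, no directly measured pair makes exactly this change, so its effect must be inferred. Compound 2 already pairs a chloro group with a 3-methoxyphenoxy group and sits at a higher number than compound 1, so the step of a 3.0-fold higher number from compound 1 to compound 4 (0.48 log units; beyond the scatter) is expected to move toward a weaker inhibitor, beyond the scatter. Compound 4 is therefore estimated at 3000 nM, with a range from 1000 nM to 10000 nM.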

Compound 4, half-maximal inhibitory concentration: 2000 nM
Compound 4: the middle estimate sits 1.5-fold (0.18 log units) above what was measured, within the range that was stated.
By their numbers in this assay, from the lowest: compound 3; then compounds 1 and 4 (each within the scatter of the next); then compound 2.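

Replacing the 3-methoxyphenoxy group with chloro on the double-bonded ring carbon gives, in this assay, a 2.0-fold higher number from compound 1 to compound 4 (0.30 log units; within the scatter). Among the compounds shown here, this is the first direct reading at this position, and it shows that a group with an aromatic ring and 9 heavy atoms can give way to a single chlorine atom without a difference that can be told from the scatter, so the two compounds cannot be ranked against each other. Nothing at hand explains this result.

The compounds shown leave open how other groups would read on this carbon, such as a plain hydrogen, a bromo group or an amine. They also leave open whether chloro in place of 3-methoxyphenoxy would read the same way on a core carrying free hydroxyls instead of methoxy groups.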